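This account rests on a few compounds, and the source may have more. Where it says the series, first, only, none or still open, it means among the compounds named here.

Compound 1, `COc1ccc(/C=C/c2cc(OC)c(OC)c(OC)c2-c2ccccc2)cc1`, in a functional assay on SK-N-SH cells (Homo sapiens) for cytotoxicity, read by MTT assay, with a stated time of 48 h (a lower number here means a stronger inhibitor, a higher number a weaker inhibitor), gives 11000 nM.
Compound 2, `COc1cc(/C=C/c2ccccc2)c(-c2ccccc2)c(OC)c1OC`, in this assay gives 63000 nM.
Compound 3, `C=C(c1ccccc1)c1cc(OC)c(OC)c(OC)c1-c1ccccc1`, in this assay gives 34000 nM.

Among these three numbers compound 3 stands second highest. Its nearest neighbour is compound 2, and that gap, a 1.9-fold lower number from compound 2 to compound 3 (0.27 log units; within the scatter), lies within the scatter; compound 1 stands further off, with the number for compound 3 higher than that for compound 1 beyond the scatter. The two steps measured so far are a 5.7-fold higher number from compound 1 to compound 2 (0.76 log units; beyond the scatter), and a 1.9-fold lower number from compound 2 to compound 3 (0.27 log units; within the scatter).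

Compound 4, `C=C(c1ccc(C(F)(F)F)cc1)c1cc(OC)c(OC)c(OC)c1-c1ccccc1`, differs from compound 3 by trifluoromethyl in place of hydrogen on an aromatic carbon. Among the compounds with values here, no measured step adds a trifluoromethyl or alters that particular ring; the one step involving the phenyl-bearing side, from compound 2 to compound 3, stayed within the scatter. With nothing in hand that speaks for a shift, compound 4 is expected to land near compound 3, with the estimated step being a 1.1-fold lower number from compound 3 to compound 4 (0.05 log units; within the scatter). The estimate for compound 4 in this assay is 30000 nM, within a range from 10000 nM to 90000 nM.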

Compound 4, half-maximal inhibitory concentration: 13000 nM
The estimate for compound 4 lay 2.3-fold (0.36 log units) above the measured number; the range from low to high includes it.
By their numbers in this assay, from the lowest: compounds 1 and 4 (each within the scatter of the next); then compounds 3 and 2 (each within the scatter of the next).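

In this assay, the change from phenyl to 4-(trifluoromethyl)phenyl gives a 2.6-fold lower number from compound 3 to compound 4 (0.42 log units; beyond the scatter), a modest step but one beyond the scatter. Within the data shown here, this is the first sign that substitution on the phenyl of the 1-phenylethenyl group, on the aromatic carbon para to a large group, moves the number, whereas the earlier step at this side, which only changed 2-phenylethenyl to 1-phenylethenyl, stayed within the scatter. Nothing available explains why this change lowers the number.

The compounds shown leave open whether this step is particular to trifluoromethyl or would also appear with another group at the same place, such as an amine, a carboxylic acid or a methoxy. They also leave open whether trifluoromethyl would give a similar step on the 2-phenylethenyl compounds.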